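A Benzyloxy Group Replaces a Bromophenyl on the Shared Core

This account rests on a few compounds, and the source may have more. Where it says the series, first, only, none or still open, it means among the compounds named here.

Of the compounds shown here, three sharing one core have been measured in a functional assay on NFF cells (Homo sapiens) for antiproliferative activity; a higher number here means a weaker inhibitor, a lower number a stronger inhibitor. Compound 1 `O=C(CCCCCC(NC(=O)c1ccco1)C(=O)NCc1ccccc1)NO` gives 4600 nM. Compound 2 `O=C(CCCCCC(NC(=O)c1ccc([N+](=O)[O-])cc1)C(=O)NCc1ccccc1)NO` gives 9000 nM. Compound 3 `O=C(CCCCC[C@H](NC(=O)c1ccc(Br)cc1)C(=O)NCc1ccccc1)NO` gives 5860 nM. Going by the values given here, the only step between two compounds that differ in one place is a 2.0-fold higher number from compound 1 to compound 2 (0.29 log units; within the scatter). Compound 3 sits among these three numbers: its gap to compound 1 and its gap to compound 2 are both within the scatter, so nothing separates it from either of them.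

Compound 4 `O=C(CCCCC[C@H](NC(=O)OCc1ccccc1)C(=O)NCc1ccccc1)NO` is the next compound to be measured. It differs from compound 3 in one place: benzyloxy in place of 4-bromophenyl on a carbonyl carbon. The change sits on the carbonyl carbon whose other neighbour is an amide-type nitrogen, the same carbon on which compound 1 and compound 2 differ. Among the compounds with values here, that step, a 2.0-fold higher number from compound 1 to compound 2 (0.29 log units; within the scatter), is the only measured change of this kind, and it stayed within the scatter. Within the data shown here, no measured step shows what a benzyloxy group does on that carbon in place of an aryl group, so the expectation rests on that single step alone.

Compound 4 is therefore expected to land close to compound 3, with a 1.0-fold higher number from compound 3 to compound 4 (0.01 log units; within the scatter) not going beyond the scatter, and its value in this assay is estimated at 6000 nM within a range from 2500 nM to 15000 nM.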

Compound 4, half-maximal inhibitory concentration: 1520 nM
The estimate for compound 4 lay 3.9-fold (0.60 log units) above the measured number; the measured number lies below the stated range.
By their numbers in this assay, from the lowest: compound 4; then compounds 1, 3 and 2 (each within the scatter of the next).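

In this assay, going by these compounds alone, a change on this carbonyl carbon, the one whose other neighbour is an amide-type nitrogen, now moves the number beyond the scatter, with a 3.9-fold lower number from compound 3 to compound 4 (0.59 log units; beyond the scatter). The only earlier step on this carbon, a 2.0-fold higher number from compound 1 to compound 2 (0.29 log units; within the scatter), exchanged one ring-bearing group for another and stayed within the scatter, so the position is not indifferent to every exchange, and replacing 4-bromophenyl with benzyloxy is the first change shown to matter here. Both groups carry one six-membered aromatic ring of carbon only, so the step goes with the entry of the oxygen and the loss of the bromine, but no measurement offered here explains it.

The compounds shown leave open which part of the exchange carries the step: a plain phenyl or a benzyl group on that carbonyl carbon would begin to separate the loss of bromine from the arrival of the oxygen. Also open, going by these compounds, is whether the ring of the benzyloxy group is needed at all, which a methoxy or tert-butoxy group on the same carbon would address.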